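Sulfonamide aryl exchange in a cinnamoyl hydroxamate series

The source may hold more compounds than are shown below. What is called first, only, known or untested is meant among the compounds shown, and "the series" means these compounds.

For the measured compounds named here, compound 1 `O=C(/C=C/c1cccc(S(=O)(=O)Nc2cccc(F)c2)c1)NO` is the only member with a reported number: in an assay for inhibition of histone deacetylase 7 (Homo sapiens), read by fluorescence, with a stated time of 3 h (a higher number here means that more compound is needed for the effect, a lower number that less compound is needed), compound 1 gives 216 nM. Compound 2 `COc1ccc(N2CCN(S(=O)(=O)c3cccc(/C=C/C(=O)NO)c3)CC2)cc1` shares the core, but in this assay the entry for compound 2 reads "not determined" (no result reported), so no result was reported for it. Compound 3 `COc1ccc(NS(=O)(=O)c2cccc(/C=C/C(=O)NO)c2)cc1` differs from compound 1 in one place: 4-methoxyphenyl in place of 3-fluorophenyl on a sulfonamide nitrogen. Going by the values given here, no step between two measured compounds is available to calibrate this change, so no shift beyond the usual scatter is expected in either direction. For compound 3 the value in this assay is estimated at 250 nM, with a range of 100 nM to 700 nM. The implied step a 1.2-fold higher number from compound 1 to compound 3 (0.06 log units; within the scatter) is expected to be small.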

Compound 3, concentration for half-maximal effect: 42 nM
Estimate against measurement, compound 3: 6.0-fold (0.77 log units) above; the measured number lies below the stated range.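

In this assay the exchange of 3-fluorophenyl for 4-methoxyphenyl on a sulfonamide nitrogen gives a 5.1-fold lower number from compound 1 to compound 3 (0.71 log units; beyond the scatter) and so marks this position as one where the choice of aryl group matters. For the compounds shown here, this is the first readable step, and it gives the position a first calibration, though from a single pair.

As far as these compounds go, whether the step follows the methoxy group, the loss of fluorine or the changed substitution pattern stays open, and 4-fluorophenyl and 3-methoxyphenyl on the same nitrogen would separate these. No measurement shown gives a reason for the step.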